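Pyrrolyl to furanyl chalcone: expected potency in HL-60 cells

This account rests on a few compounds, and the source may have more. Where it says the series, first, only, none or still open, it means among the compounds named here.

Measured so far:
compound 1 `O=C(/C=C/c1cccc([N+](=O)[O-])c1)c1ccc[nH]1` — 20000 nM
compound 2 `COc1cccc(/C=C/C(=O)c2ccc[nH]2)c1` — 16000 nM

In a functional assay on HL-60 cells (Homo sapiens) for inhibition, read by MTT assay, with a stated time of 48 h (a higher number here means a weaker inhibitor, a lower number a stronger inhibitor), compound 1 gives 20000 nM, the highest of the two numbers; its nearest neighbour is compound 2, which gives 16000 nM. Among the compounds with values here, the one measured step, a 1.3-fold lower number from compound 1 to compound 2 (0.10 log units; within the scatter), concerns the group on the aromatic ring and lies within the scatter.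

Compound 3 `O=C(/C=C/c1cccc([N+](=O)[O-])c1)c1ccco1` differs from compound 1 at the carbonyl carbon: furan-2-yl in place of 1H-pyrrol-2-yl on a carbonyl carbon. Within the data shown here, no measured step touches this carbonyl side of the shared core, so the step from compound 1 to compound 2 does not bear on it and offers no direction. With nothing to argue for a shift beyond the scatter, the step is expected to be no change at the digits printed from compound 1 to compound 3 (within the scatter). The estimate for compound 3 in this assay is therefore 20000 nM, with a range from 7000 nM to 60000 nM.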

Compound 3, half-maximal inhibitory concentration: 14000 nM
Compound 3: the middle estimate sits 1.4-fold (0.15 log units) above what was measured; low and high end bracket the measured number.
By their numbers in this assay, from the lowest: compounds 3, 2 and 1 (each within the scatter of the next).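

Where the earlier compounds varied only the group on the aromatic ring, compound 3 changes the carbonyl side of the shared core: furan-2-yl in place of 1H-pyrrol-2-yl on a carbonyl carbon gives a 1.4-fold lower number from compound 1 to compound 3 (0.15 log units; within the scatter) in this assay. The change exchanges the hydrogen-bond donor of 1H-pyrrol-2-yl for the hydrogen-bond acceptor of furan-2-yl, and in this one pair the number does not move beyond the scatter. Nothing available here explains why the two compounds read alike.

Going by these compounds, it remains open whether a thiophen-2-yl or a phenyl group on the carbonyl carbon would give a step beyond the scatter. On these data alone, it is also open whether furan-2-yl combined with the methoxy group of compound 2 would read differently.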